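Swapping a propyl chain for a cyclobutyl ring

The source may hold more compounds than are shown below. What is called first, only, known or untested is meant among the compounds shown, and "the series" means these compounds.

Of the compounds shown here, three share one core and have been tested in an assay for inhibition of Pro-cathepsin H (Homo sapiens), read by fluorescence, tested at 50 uM; a lower number here means less inhibition, a higher number more inhibition at the concentration tested (going by the name of the read-out). Compound 1 `O=c1nc(SCc2ccccc2)nc(SCc2cccc(F)c2)[nH]1` gives 4.18%, compound 2 `O=c1nc(SCc2ccccc2)nc(SCc2ccc(Cl)cc2)[nH]1` gives 6.91%, and compound 3 `CCCCSc1nc(SCc2ccccc2)nc(=O)[nH]1` gives -1.81%. Compound 3 holds the lowest of the three numbers, though every gap among them stays within the scatter: a number 2.7 percentage points higher from compound 1 to compound 2 (within the scatter), a number 6 percentage points lower from compound 1 to compound 3 (within the scatter) and a number 8.7 percentage points lower from compound 2 to compound 3 (within the scatter). Compound 4 `O=c1nc(SCc2ccccc2)nc(SCC2CCC2)[nH]1` differs from compound 3 in one place: cyclobutyl in place of propyl on a saturated chain carbon bound to a sulfur. The two steps that bear on this, from compound 1 and from compound 2 to compound 3, each changed the same position and each stayed within the scatter, so no step beyond the scatter is expected in this assay. The estimate for compound 4 is 1%, within -8% to 10%, an expected step of a number 2.8 percentage points higher from compound 3 to compound 4 (within the scatter).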

Compound 4, a percentage reported as inhibition, at one concentration (the size of the read-out at that concentration, not a potency): 1.57%
Compound 4: middle estimate off by 0.6 percentage points, on the low side, and the stated range covers the measured number.
By their numbers in this assay, from the lowest: compounds 3, 4, 1 and 2 (each within the scatter of the next).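

A step of a number 3.4 percentage points higher from compound 3 to compound 4 (within the scatter) shows that in this assay closing the carbon chain into a four-membered ring, on a saturated chain carbon bound to a sulfur, gives no readable change. Steps a number 5.3 percentage points lower from compound 2 to compound 4 (within the scatter) and a number 2.6 percentage points lower from compound 1 to compound 4 (within the scatter) show that cyclobutyl also cannot be told apart from either substituted phenyl group. This position has therefore now held a chain, a non-aromatic ring and aromatic rings with no step beyond the scatter. Nothing available explains this flat picture. From the compounds shown here alone, whether an amine or a carboxylic acid at this position would give a step beyond the scatter remains open.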